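Testing a methoxyphenyl swap on a shared core

The source may hold more compounds than are shown below. What is called first, only, known or untested is meant among the compounds shown, and "the series" means these compounds.

Of the compounds shown here, three built on one shared core have been tested in a functional assay on A549 cells (Homo sapiens) for antiproliferative activity, read by MTT assay; on this read-out lower numbers stand for stronger inhibition and higher numbers for weaker inhibition. Compound 1 `Cn1c(=O)c(=O)n(C2CCCC2)c2nc(N/N=C/c3ccc(O)c(F)c3)ncc21` gives 97800 nM in this assay, the highest of the three numbers, which on this read-out means the weakest inhibition of cell growth. Compound 2 `Cn1c(=O)c(=O)n(C2CCCC2)c2nc(N/N=C/c3ccc(C(F)(F)F)cc3)ncc21` gives 40600 nM, and compound 3 `Cn1c(=O)c(=O)n(C2CCCC2)c2nc(N/N=C/c3cc(C(F)(F)F)c(O)c(C(F)(F)F)c3)ncc21` gives 22900 nM; both of these numbers lie beyond the scatter below that of compound 1.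

Compound 4 `COc1ccc(/C=N/Nc2ncc3c(n2)n(C2CCCC2)c(=O)c(=O)n3C)cc1` has not yet been measured. It differs from compound 1 in one place: 4-methoxyphenyl in place of 3-fluoro-4-hydroxyphenyl on a carbon with a double bond to nitrogen. Within the data shown here, one measured step bears on this change, namely a 2.4-fold lower number from compound 1 to compound 2 (0.38 log units; beyond the scatter), in which the same 3-fluoro-4-hydroxyphenyl group was also replaced by a phenyl ring carrying a single group, there a trifluoromethyl. As with that change, the entering 4-methoxyphenyl keeps one hydrogen-bond acceptor and drops the hydrogen-bond donor. A modest lowering of the number is therefore expected for compound 4, while the different entering group leaves room for the step to stay within the scatter. For compound 4 the expected result in this assay is 55000 nM, within a range from 25000 nM to 120000 nM, corresponding to an expected step of a 1.8-fold lower number from compound 1 to compound 4 (0.25 log units; within the scatter).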

Compound 4, half-maximal inhibitory concentration: > 100000 nM
Compound 4 gave a limit, no number; the forecaster's own chance of this, stated with the estimate: 10%; middle value at least 1.8-fold (0.25 log units) from the limit.
By their numbers in this assay, from the lowest: compounds 3 and 2 (each within the scatter of the next); then compound 1. At a limit, above all of these: compound 4.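

In this assay compound 4 gives a limit of the assay and not a number: the limit of > 100000 nM in this assay, at which 1 of the 4 values shown sits.

Methoxy in place of trifluoromethyl on an aromatic carbon gives a step beyond the scatter (the step is an at least 2.4-fold higher number from compound 2 to compound 4 (0.39 log units; beyond the scatter)), so the group carried by this phenyl ring does matter, and a ring with a single group does not lower the number in every case. The change from 3-fluoro-4-hydroxyphenyl to 4-methoxyphenyl gives only a floor (the step is an at least 1.0-fold higher number from compound 1 to compound 4 (0.00 log units; that floor lies within the scatter)), which cannot separate the two groups, yet the lowering seen with compound 2 does not carry over to compound 4, whose entering group has no hydrogen-bond donor, so the missing donor alone does not account for that lowering.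

As far as these compounds go, how far the true value of compound 4 lies past its limit stays open, and with it the real size of both steps. Also open, from the compounds shown here alone, is whether a nitrile or a dimethylamino group in place of methoxy on an aromatic carbon would fall with compound 2 or with compound 4.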